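The compounds below may be only part of what the source reports. "The series", "measured", "known", "first", "only" and "open" are said of these compounds alone.

Working notes on the series, read in a functional assay on UACC-62 cells (Homo sapiens); a higher number here means a weaker inhibitor of growth, a lower number a stronger inhibitor of growth. Compound 1 (`O=S(=O)(/C=C/c1ccc(Cl)c(Cl)c1)Cc1ccc(Nc2ncnc3ccc(Br)cc23)cc1`) gives 30000 nM and compound 2 (`O=S(=O)(/C=C/c1ccc(C(F)(F)F)cc1F)Cc1ccc(Nc2ncnc3ccc(Br)cc23)cc1`) gives 22000 nM. Among the measured compounds shown here, these two values lie within the scatter of each other, so compound 2 stands level with compound 1 on the numbers so far. Compound 3 (`O=S(=O)(/C=C/c1ccc(C(F)(F)F)cc1F)Cc1ccc(Nc2ncnc3cc(Cl)ccc23)cc1`) keeps the rest of compound 2 and carries one change: a group of 11 heavy atoms (8 carbon, 2 nitrogen, 1 chlorine; one six-membered aromatic ring of carbon only, one six-membered aromatic ring with 2 hetero atoms) in place of a group of 11 heavy atoms (8 carbon, 2 nitrogen, 1 bromine; one six-membered aromatic ring of carbon only, one six-membered aromatic ring with 2 hetero atoms), on a nitrogen on an aromatic ring. For the measured compounds named here, the only measured step is a 1.4-fold lower number from compound 1 to compound 2 (0.13 log units; within the scatter), and it concerns a different place, the group on the double-bonded chain carbon. Going by the values given here, no measured step covers a change on the nitrogen on an aromatic ring, so the data give no size for it, and no step beyond the scatter is expected in this assay. The expected step is a 1.1-fold lower number from compound 2 to compound 3 (0.04 log units; within the scatter). Compound 3 is estimated at 20000 nM, with an expected range of 8000 nM to 50000 nM.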

Compound 3, concentration for 50% growth inhibition: > 100000 nM
Compound 3: no number, only a limit; the forecaster's own chance of this, stated with the estimate: 10%; at least 5.0-fold (0.69 log units) between middle value and limit.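

In this assay compound 3 gives > 100000 nM, which is a limit of the assay and not a number. Among the compounds shown here, the group on the nitrogen on an aromatic ring is the first place to show a step beyond the scatter, an at least 4.5-fold higher number from compound 2 to compound 3 (0.65 log units; beyond the scatter), whereas the change on the double-bonded chain carbon gave a 1.4-fold lower number from compound 1 to compound 2 (0.13 log units; within the scatter), even though the two groups here match in heavy-atom count, donors and acceptors. The size of the step stays open, and only its lower bound can be read: the limit of > 100000 nM in this assay, at which 1 of the 3 values shown sits.

The compounds shown do not separate the loss of bromine from the arrival of the chlorine as it sits in 7-chloroquinazolin-4-yl. They also leave open whether a methoxy group or an amine in place of that chlorine would bring the read-out back within range of the assay.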